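Hydrazone aryl variation: pyridin-2-yl enters in compound 4

The source may report more compounds than this note shows. Statements on the series, on what has been measured and on what is new or still open speak of the compounds shown alone.

Measured so far in a functional assay on the whole organism with Rattus norvegicus as the target; on this read-out lower numbers stand for an effect already at smaller amounts and higher numbers for an effect only at larger amounts of compound:
- Compound 1 `Cc1ccc(NN=C2CCC(C)n3c2ncc(C(=O)O)c3=O)cc1C`: in this assay compound 1 reaches only the assay limit, > 100 umol/kg.
- Compound 2 `COc1cc(NN=C2CCC(C)n3c2ncc(C(=O)O)c3=O)cc(OC)c1`: in this assay compound 2 gives 100 umol/kg.
- Compound 3 `CC1CCC(=NNc2ccc3ccccc3c2)c2ncc(C(=O)O)c(=O)n21`: in this assay compound 3 likewise stops at the limit, > 100 umol/kg.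

Compound 1 stands at the limit of > 100 umol/kg in this assay, at which 2 of the 3 values shown sit. For the measured compounds named here, the two limit readings and the single number for compound 2 all sit at the same level, so no order among the three measured compounds can be drawn, and no step between any pair of them has been worked out.

Compound 4 `CC1CCC(=NNc2ccccn2)c2ncc(C(=O)O)c(=O)n21` is the next one to be measured. Its difference from compound 1 is pyridin-2-yl in place of 3,4-dimethylphenyl on an amine nitrogen. Across the three measured compounds, the aryl group on the hydrazone nitrogen has been varied from a dimethylated to a dimethoxylated to a fused bicyclic aromatic ring without any reading leaving the limit region. On that basis the step of a number no higher from compound 1 to compound 4 (the limit leaves the size open) is expected to be none beyond the scatter, though with a limit reading again a likely outcome. Compound 4 is estimated at 100 umol/kg, with a range from 30 umol/kg to 300 umol/kg.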

Compound 4, dose for 50% inhibition: > 100 umol/kg
Compound 4: only a limit was reported (the forecaster's own chance of this, stated with the estimate: 60%); the middle value lies on the limit itself.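

In this assay compound 4 gives > 100 umol/kg as a limit of the assay. Compound 1 gives > 100 umol/kg as a limit too, and no step between the two can be read: the limit of > 100 umol/kg in this assay, at which 3 of the 4 values shown sit.

The compounds shown leave open whether pyridin-2-yl and 3,4-dimethylphenyl differ at all on this read-out.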